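A Dichlorophenyl Swap Checked for Liver Cell Toxicity

The source may report more compounds than this note shows. Statements on the series, on what has been measured and on what is new or still open speak of the compounds shown alone.

In an ADME assay on HepG2 cells (Homo sapiens) for cytotoxicity, read by CellTiter-Glo and resazurin assay, with a stated time of 72 h (a lower number here means that less compound is needed, a higher number that more compound is needed for the effect), compound 3 `CCOc1cccc(-c2ccc(C(=O)N(Cc3cccc(OCCCCCC(=O)O)c3)C(C)C)cc2)c1` reaches only a limit of the assay, > 20800 nM, and not a number. Compound 1 `CC(C)N(Cc1cccc(OCCCCCC(=O)O)c1)C(=O)c1ccccc1` likewise stops at a limit, > 26000 nM. Compound 2 `CC(C)N(Cc1cccc(OCCCCCC(=O)O)c1)C(=O)c1ccc(-c2cccc(-c3ccccc3)c2)cc1` also gives only a limit, > 26000 nM. Compound 4 `CC(C)N(Cc1cccc(OCCCCCC(=O)O)c1)C(=O)c1ccc(-c2ccc(Cl)c(Cl)c2)cc1` differs from compound 3 at a single place: 3,4-dichlorophenyl in place of 3-ethoxyphenyl on an aromatic carbon. The measured steps that touch compound 3 are a step that the two limits leave unreadable from compound 1 to compound 3 and a step that the two limits leave unreadable from compound 2 to compound 3; both run between limits, so their size cannot be read, as the limit of > 20800 nM in this assay, at which 1 of the 3 values shown sits, and the limit of > 26000 nM in this assay, at which 2 of the 3 values shown sit, show. No step beyond the usual scatter is expected in this assay for compound 4, which is estimated at 25000 nM, within 10000 nM to 60000 nM, an expected step that the limit leaves unreadable from compound 3 to compound 4.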

Compound 4, half-maximal effective concentration: > 26000 nM
Compound 4 ended at the assay's limit; the forecaster's own chance of this, stated with the estimate: 80%; at least 1.0-fold (0.01 log units) between middle value and limit.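

Among the compounds shown here, compound 4 ends at a limit of the assay, as do compound 1, compound 2 and compound 3, and no step among them can be read. The compounds shown leave open what concentration, if any, produces the half-maximal effect on these liver cells, and whether swapping these groups changes it.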